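Thiophene to Furan on the Saturated Ring Carbon

A few compounds are considered here, and "the series" means these few. Any claim that something is new, unique, unknown or untested is made for them only; others in the source may bear on it.

Compound 1 `CC1=C(C(=O)OC(C)C)C(C2CCCC2)N/C(=N/C#N)N1` gives 3%. Compound 2 `CCOC(=O)C1=C(C)N/C(=N\C#N)NC1c1ccoc1` gives 28%. Compound 3 `CC1=C(C(=O)OC(C)C)C(c2cccs2)N/C(=N/C#N)N1` gives 31%.

In an assay on cells for displacement of a labelled ligand from adenosine receptor A1 (Homo sapiens), with a stated time of 60 min, tested at 1 uM (a higher number here means more inhibition at the concentration tested (going by the name of the read-out), a lower number less inhibition), compound 3 stands highest of the three numbers, though compound 2 sits within the scatter of it, while compound 1 lies well below. Compound 4 `CC1=C(C(=O)OC(C)C)C(c2ccoc2)N/C(=N/C#N)N1` differs from compound 3 by furan-3-yl in place of thiophen-2-yl on a saturated ring carbon. Going by the values given here, the only measured step, a number 28 percentage points higher from compound 1 to compound 3 (beyond the scatter), concerns the arrival of a five-membered aromatic ring and does not test the swap of thiophen-2-yl for furan-3-yl. Compound 2, which carries furan-3-yl but differs from compound 4 elsewhere, gives a number within the scatter of compound 3. Compound 4 is therefore expected to show a number 2 percentage points lower from compound 3 to compound 4 (within the scatter), nothing beyond the scatter. The estimate for compound 4 is 29%, within 15% to 43%.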

Compound 4, a percentage reported as inhibition, at one concentration (the size of the read-out at that concentration, not a potency): 34%
Beside the measured number, compound 4's estimate is 5 percentage points below it; the range from low to high includes it.
By their numbers in this assay, from the lowest: compound 1; then compounds 2, 3 and 4 (each within the scatter of the next).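

In this assay, the two five-membered aromatic rings cannot be told apart at this saturated ring carbon (a number 3 percentage points higher from compound 3 to compound 4 (within the scatter)). With furan-3-yl in place, methyl in place of hydrogen on the chain of the ester also gives no readable change (a number 6 percentage points higher from compound 2 to compound 4 (within the scatter)). The rise over cyclopentyl is not confined to thiophen-2-yl, as furan-3-yl shows it too (a number 31 percentage points higher from compound 1 to compound 4 (beyond the scatter)).

From the compounds shown here alone, how a phenyl or pyridin-3-yl ring would fare at this carbon stays open. No measurement shown here explains any of these numbers.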